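The source may hold more compounds than are shown below. What is called first, only, known or untested is meant among the compounds shown, and "the series" means these compounds.

Measured compounds:
compound 1 `C[C@@H]1CN(Cc2ccccc2)c2nc(C(F)(F)F)ccc2[C@H](C)N1C(=O)NCc1ccccc1`: 281 nM
compound 2 `C[C@@H]1CN(Cc2ccccc2)c2nc(F)ccc2[C@H](C)N1C(=O)NCc1ccccc1`: 4 nM
compound 3 `C[C@@H]1CN(Cc2ccccc2)c2ncccc2[C@H](C)N1C(=O)NCc1ccccc1`: 8 nM

All numbers come from an assay on HEK293 cells for inhibition of Voltage-dependent T-type calcium channel subunit alpha-1I (Homo sapiens), read by FLIPR and calcium flux, with a stated time of 3 min; a higher number here means a weaker inhibitor, a lower number a stronger inhibitor. Compound 3 sits second highest of the three; its nearest neighbour is compound 2, separated by a 2.0-fold higher number from compound 2 to compound 3 (0.30 log units; within the scatter), which lies within the scatter, while compound 1 lies furthest away, a 35-fold lower number from compound 1 to compound 3 (1.55 log units; beyond the scatter). The step to compound 4 `C[C@@H]1CN(Cc2ccccc2)c2ncc(F)cc2[C@H](C)N1C(=O)NCc1ccccc1` is fluoro in place of hydrogen on an aromatic carbon. For the measured compounds named here, only one measured step concerns a single fluorine on the aromatic ring, a 2.0-fold higher number from compound 2 to compound 3 (0.30 log units; within the scatter), and it lies within the scatter; that fluorine, however, stood where the trifluoromethyl of compound 1 had been, not at the position changed here, so it bears on the new step only loosely. The large steps of a 70-fold lower number from compound 1 to compound 2 (1.85 log units; beyond the scatter) and a 35-fold lower number from compound 1 to compound 3 (1.55 log units; beyond the scatter) concern the trifluoromethyl and say nothing about adding a fluorine elsewhere. Going by the values given here, no measured compound carries a substituent at the position changed in compound 4, so its effect there is unknown. On that basis the expected step is a 1.1-fold lower number from compound 3 to compound 4 (0.06 log units; within the scatter), none beyond the scatter, with the range widened for the untested position. Compound 4 is therefore estimated at 7 nM in this assay, with an expected range from 2.5 nM to 25 nM.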

Compound 4, half-maximal inhibitory concentration: 15 nM
For compound 4 the middle estimate is 2.1-fold (0.33 log units) below the measured one; measured number inside the range.
By their numbers in this assay, from the lowest: compounds 2, 3 and 4 (each within the scatter of the next, the first and the last beyond it); then compound 1.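

In this assay, fluoro in place of hydrogen on the aromatic carbon two atoms from the ring nitrogen gives a 1.9-fold higher number from compound 3 to compound 4 (0.27 log units; within the scatter), which lies within the scatter, so this position accepts a fluorine without a change that can be told from repeat measurement. For the compounds shown here, the earlier steps covered only the site that carried the trifluoromethyl of compound 1, and compound 4 adds a first reading at a second site on the same aromatic ring, showing that the steep loss seen at that first site does not appear with fluoro here. No measurement at hand offers a reason for this result.

Still open, from the compounds shown here alone, is how this carbon responds to groups other than fluoro, such as a chlorine, a methoxy group, a nitrile, an amine or the trifluoromethyl itself, since a 35-fold lower number from compound 1 to compound 3 (1.55 log units; beyond the scatter) describes a different site and cannot be carried over to this one. Also open, going by these compounds, is whether a fluorine at this position and one at the site occupied in compound 2 would combine on the shared core.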